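Aryl swaps on the ring amide nitrogen: outlook for compound 4

The source may hold more compounds than are shown below. What is called first, only, known or untested is meant among the compounds shown, and "the series" means these compounds.

The series shares one core: compound 1 `CO[C@@H]1CC=C2N(c3ccc([N+](=O)[O-])cc3)C(=O)C[C@]2(c2ccccc2)O1`, compound 2 `CO[C@@H]1CC=C2N(c3ccccn3)C(=O)C[C@]2(c2ccccc2)O1` and compound 3 `CO[C@@H]1CC=C2N(c3c[nH]c4ccccc34)C(=O)C[C@]2(c2ccccc2)O1` differ only in the group on the amide-type nitrogen in the ring. In a functional assay on HCT-116 cells (Homo sapiens) for cytotoxicity, read by sulforhodamine B assay, with a stated time of 48 h (a higher number here means a weaker inhibitor, a lower number a stronger inhibitor), compound 1 gives 8000 nM, compound 2 gives 7300 nM, and compound 3 gives 7130 nM. Compound 3 carries the lowest of the three numbers, but the steps of a 1.1-fold lower number from compound 1 to compound 3 (0.05 log units; within the scatter) and a 1.0-fold lower number from compound 2 to compound 3 (0.01 log units; within the scatter) are both within the scatter, as is a 1.1-fold lower number from compound 1 to compound 2 (0.04 log units; within the scatter); the three values cannot be put in order.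

Compound 4 `CO[C@@H]1CC=C2N(c3cc(Cl)cc(Cl)c3)C(=O)C[C@]2(c2ccccc2)O1` is the next member of the set: 3,5-dichlorophenyl in place of 1H-indol-3-yl on an amide-type nitrogen in a ring. Every measured step concerns this same position, and none of them moved the number beyond the scatter, so the change to compound 4 is expected to leave this assay unchanged within the scatter: a 1.0-fold higher number from compound 3 to compound 4 (0.01 log units; within the scatter). Compound 4 is therefore estimated at 7300 nM, with a range of 3500 nM to 15000 nM.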

Compound 4, half-maximal inhibitory concentration: 11200 nM
Compound 4: middle estimate off by 1.5-fold (0.19 log units), on the low side; the measured number falls inside the stated range.
By their numbers in this assay, from the lowest: compounds 3, 2, 1 and 4 (each within the scatter of the next).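

In this assay, going by these compounds alone, the 3,5-dichlorophenyl group, the only chlorine-bearing group here, stays within the scatter of all three earlier groups (a 1.6-fold higher number from compound 3 to compound 4 (0.20 log units; within the scatter); a 1.5-fold higher number from compound 2 to compound 4 (0.19 log units; within the scatter); a 1.4-fold higher number from compound 1 to compound 4 (0.15 log units; within the scatter)). The amide-type nitrogen in the ring now carries four different aromatic groups with no step beyond the scatter, and the change from 1H-indol-3-yl, with its hydrogen-bond donor, to a group with none does not separate compound 4 from compound 3. No measured evidence accounts for these groups reading alike.

Still open, going by these compounds, is whether a non-aromatic group on this nitrogen, such as methyl or an aminoethyl chain, or a carboxylic acid on the phenyl ring there, would give a step beyond the scatter. Also open, on these data alone, is how the number responds to replacing the phenyl group on the shared core, which all four compounds keep.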